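The source may hold more compounds than are shown below. What is called first, only, known or untested is meant among the compounds shown, and "the series" means these compounds.

Of the compounds shown here, two have so far been measured in a functional assay on B16-F10 cells (Mus musculus) for antiproliferative activity, read by MTT assay, with a stated time of 72 h; a lower number here means a stronger inhibitor, a higher number a weaker inhibitor. Compound 1 `CC(=O)Oc1ccc(/C=C/C(=O)OCCSc2nc(-c3ccc(S(C)(=O)=O)cc3)n(-c3ccc(C(F)(F)F)cc3)n2)cc1OC(C)=O` gives 11500 nM in this assay. Compound 2 `CS(=O)(=O)c1ccc(-c2nc(SCCCNC(=O)/C=C/c3ccc(O)c(O)c3)nn2-c2ccc(F)cc2)cc1` differs from compound 1 in several places at once; in this assay compound 2 gives 18700 nM, and the two numbers lie within the scatter of each other, so neither compound stands apart from the other. Compound 3 `COc1cc(/C=C/C(=O)OCCSc2nc(-c3ccc(S(C)(=O)=O)cc3)n(-c3ccc(C(F)(F)F)cc3)n2)ccc1OC(C)=O` has not yet been measured. It differs from compound 1 in a single place: methyl in place of acetyl on an oxygen on an aromatic ring. Among the compounds with values here, no pair of measured compounds shows this change on its own, and compound 2 differs from compound 1 at too many points to serve as a guide. With nothing to point in either direction, compound 3 is expected to land close to compound 1. The expected step is a 1.0-fold lower number from compound 1 to compound 3 (0.02 log units; within the scatter), within the scatter. Compound 3 is therefore estimated at 11000 nM, with a range from 4500 nM to 27000 nM.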

Compound 3, half-maximal inhibitory concentration: 10500 nM
Estimate against measurement, compound 3: 1.0-fold (0.02 log units) above; the measured number falls inside the stated range.
By their numbers in this assay, from the lowest: compounds 3, 1 and 2 (each within the scatter of the next).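

In this assay, replacing acetoxy with methoxy gives a 1.1-fold lower number from compound 1 to compound 3 (0.04 log units; within the scatter), so this one change leaves the reading indistinguishable from that of the parent compound. Within the data shown here, the methyl brings one heavy atom where the acetyl had three, and no hydrogen-bond acceptor where the acetyl had one, yet this difference produces no step that can be told from the scatter. Nothing measured here accounts for this outcome.

Going by these compounds, whether a longer chain on this oxygen, such as an ethyl or a propyl group, or a chain ending in an amine or a carboxylic acid, would also leave the reading unchanged remains open. This is a single pair in a single assay, so it cannot show whether the same swap would behave alike on a different core.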